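The source may hold more compounds than are shown below. What is called first, only, known or untested is meant among the compounds shown, and "the series" means these compounds.

Measured in an in vitro ADME assay on microsomes from liver (Simiiformes) (a lower number here means that the compound disappears faster, a higher number that the compound lasts longer), the compounds give these values
compound 1 `Cc1cc(CCCOc2c(C)cc(-c3noc(C)n3)cc2C)on1` gives 0.45 h
compound 2 `Cc1cc(CCCOc2c(C)cc(-c3noc(CF)n3)cc2C)on1` gives 0.233 h
compound 3 `Cc1cc(CCCOc2c(C)cc(-c3noc(C(Cl)(Cl)Cl)n3)cc2C)on1` gives 0.183 h

Compound 1 holds the highest of these three numbers, but only one of its gaps is clear: a 2.5-fold lower number from compound 1 to compound 3 (0.39 log units; beyond the scatter) lies beyond the scatter, while a 1.9-fold lower number from compound 1 to compound 2 (0.29 log units; within the scatter) does not. The remaining step, a 1.3-fold lower number from compound 2 to compound 3 (0.10 log units; within the scatter) also stays within the scatter.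

Compound 4 `Cc1ccc(CCCOc2c(C)cc(-c3noc(C)n3)cc2C)cn1` keeps the methyl group that those steps alter and differs elsewhere 6-methylpyridin-3-yl in place of 3-methyl-1,2-oxazol-5-yl on a saturated chain carbon, three bonds along the chain from an oxygen on an aromatic ring with 6-methylpyridin-3-yl in place of 3-methyl-1,2-oxazol-5-yl on a saturated chain carbon, three bonds along the chain from an oxygen on an aromatic ring.

Within the data shown here, no measured step touches this place, so the three steps bear on it only indirectly. They show how far the numbers have moved in this small set, and even the largest, a 2.5-fold lower number from compound 1 to compound 3 (0.39 log units; beyond the scatter) is modest. With no direct evidence for the new group, the starting point remains compound 1 at 0.45 h and no change beyond the scatter is expected in this assay in either direction. The expected step is a 1.1-fold lower number from compound 1 to compound 4 (0.05 log units; within the scatter) and this estimate is an uncertain one. Compound 4 is expected at 0.4 h and its estimated range runs from 0.15 h to 1 h on present evidence.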

Compound 4, half-life: 1.37 h
Compound 4: middle estimate off by 3.4-fold (0.53 log units), on the low side; measured number above the stated range.
By their numbers in this assay, from the lowest: compounds 3, 2 and 1 (each within the scatter of the next, the first and the last beyond it); then compound 4.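

In this assay, the place on the saturated chain carbon, three bonds along the chain from an oxygen on an aromatic ring, proves able to shift the half-life, and the exchange of 3-methyl-1,2-oxazol-5-yl for 6-methylpyridin-3-yl gives a 3.0-fold higher number from compound 1 to compound 4 (0.48 log units; beyond the scatter) as a step beyond the scatter. Compound 1, compound 2 and compound 3 differ at another place, and none of their listed steps gives a higher number, so this is the first change in the set to move the half-life upward. Nothing measured here explains the rise, which therefore stands as an observation about this one exchange on the core of compound 1.

The compounds shown leave open whether the rise belongs to the six-membered ring as such or to its methyl group, a question that a plain phenyl or a pyridin-3-yl without the methyl would address. Also open, from the compounds shown here alone, is whether 6-methylpyridin-3-yl has a similar effect when fluoromethyl or trichloromethyl replaces the methyl group changed in compound 2 and compound 3, or when it sits on a longer chain.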